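The compounds below may be only part of what the source reports. "The series", "measured", "known", "first", "only" and "open" are said of these compounds alone.

Compound 1 `O=C(O)C[C@H](O)C[C@H](O)CCn1c(C(F)(F)F)nc(-c2ccccc2)c1-c1ccc(F)cc1` carries a phenyl group on its shared core, and in an assay on microsomes from liver for inhibition of 3-hydroxy-3-methylglutaryl-coenzyme A reductase (Rattus norvegicus) (on this read-out lower numbers stand for stronger inhibition and higher numbers for weaker inhibition), compound 1 gives 31 nM. Compound 2 `O=C(O)C[C@H](O)C[C@H](O)CCn1c(C(F)(F)F)nc(-c2ccc(F)cc2)c1-c1ccc(F)cc1` differs from it in one place: fluoro in place of hydrogen on an aromatic carbon. In this assay compound 2 gives 38 nM, so the step is a 1.2-fold higher number from compound 1 to compound 2 (0.09 log units; within the scatter). Compound 3 `Cc1cc(C)cc(-c2nc(C(F)(F)F)n(CC[C@@H](O)C[C@@H](O)CC(=O)O)c2-c2ccc(F)cc2)c1` keeps the core of compound 1 but changes the phenyl group: 3,5-dimethylphenyl in place of phenyl on an aromatic carbon. In this assay compound 3 gives 24 nM; the steps are a 1.3-fold lower number from compound 1 to compound 3 (0.11 log units; within the scatter) and a 1.6-fold lower number from compound 2 to compound 3 (0.20 log units; within the scatter), and all three numbers lie close together.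

Compound 4 `Cc1cc(-c2nc(C(F)(F)F)n(CC[C@@H](O)C[C@@H](O)CC(=O)O)c2-c2ccc(F)cc2)cc(C)c1F` is not yet measured. It differs from compound 3 in one place: fluoro in place of hydrogen on an aromatic carbon. This is the same kind of change as the one from compound 1 to compound 2, and it has been seen only that once among these compounds. The surroundings are not the same, though: in compound 4 the entering fluoro sits ortho to two methyl groups as well as para to a large group, whereas in compound 2 it sits only para to a large group.

From compound 3 to compound 4 the expected step is a 1.2-fold higher number from compound 3 to compound 4 (0.07 log units; within the scatter), and this expectation rests on the small step of a 1.2-fold higher number from compound 1 to compound 2 (0.09 log units; within the scatter) seen for the same kind of change. Among the compounds with values here, for compound 4 the estimate in this assay is 28 nM, with a range from 14 nM to 56 nM, the range being wide because a single earlier step, a 1.2-fold higher number from compound 1 to compound 2 (0.09 log units; within the scatter), is the only guide.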

Compound 4, half-maximal inhibitory concentration: 32 nM
Compound 4: middle estimate off by 1.1-fold (0.06 log units), on the low side; low and high end bracket the measured number.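

In this assay the fluoro change on the dimethylated ring gives the step of a 1.3-fold higher number from compound 3 to compound 4 (0.12 log units; within the scatter) and stays small, and the two other new steps of a 1.2-fold lower number from compound 2 to compound 4 (0.07 log units; within the scatter) and a 1.0-fold higher number from compound 1 to compound 4 (0.01 log units; within the scatter) are small as well. Set beside the earlier case, the same change reads alike on the two cores: the same change on two cores in this assay, a 1.2-fold higher number (0.09 log units; within the scatter) from compound 1 to compound 2 and a 1.3-fold higher number (0.12 log units; within the scatter) from compound 3 to compound 4, 1.1-fold (0.04 log units) apart, within the scatter of two such steps. This shows that fluoro in place of hydrogen moved the number by no more than the usual scatter in both surroundings, whether or not the entering fluoro sits ortho to two methyl groups, but with only two cases, and every step within the scatter, it gives no real direction for the change, no ranking of these four compounds, and no assurance about any further core in the series.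

The compounds shown leave open what a different group would do at this same place, such as a chloro, a methoxy, an amine or a carboxylic acid in place of the fluoro. They also leave open whether the quiet behaviour of this aromatic ring would hold if the trifluoromethyl group or the 4-fluorophenyl ring on the shared core were replaced by something else.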